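Swapping a phenol for a dichlorophenyl in a thiosemicarbazone series

This account rests on a few compounds, and the source may have more. Where it says the series, first, only, none or still open, it means among the compounds named here.

The series shares an isatin-derived thiosemicarbazone core carrying an aryl group on a carbon with a double bond to nitrogen. Compound 2 `COc1ccc(/C=N/NC(=S)N/N=C2\C(=O)Nc3ccc(C)cc32)cc1O` gives 2730 nM in a functional assay on HeLa cells (Homo sapiens) for inhibition, read by MTT assay (a lower number here means a stronger inhibitor, a higher number a weaker inhibitor), the highest of the two numbers recorded, with compound 3 `COc1ccc(/C=N/NC(=S)N/N=C2\C(=O)Nc3ccc(Br)cc32)cc1O` nearest at 2220 nM; the step of a 1.2-fold lower number from compound 2 to compound 3 (0.09 log units; within the scatter) changes only the core substituent. Compound 1 `O=C1Nc2ccc(Br)cc2/C1=N/NC(=S)N/N=C/c1ccccc1Br` reaches only the limit > 50000 nM in this assay. Going by the values given here, the one step that touches the aryl group, an at least 22-fold lower number from compound 1 to compound 3 (1.35 log units; beyond the scatter), is the most telling here, although its size rests on the limit (the limit of > 50000 nM in this assay, at which 1 of the 3 values shown sits).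

Compound 4 `Cc1ccc2c(c1)/C(=N/NC(=S)N/N=C/c1c(Cl)cccc1Cl)C(=O)N2` is compound 2 with 2,6-dichlorophenyl in place of 3-hydroxy-4-methoxyphenyl on a carbon with a double bond to nitrogen. This runs the aryl change of compound 1 to compound 3 in the opposite direction, since 2,6-dichlorophenyl, like the 2-bromophenyl of compound 1, is a phenyl bearing halogen and lacking the hydroxyl and methoxy of compound 2. A large rise in number is therefore expected for compound 4 in this assay, with a real chance that only a limit is returned, an estimated step of a 15-fold higher number from compound 2 to compound 4 (1.17 log units; beyond the scatter). Compound 4 is estimated at 40000 nM, within a range from 8000 nM to 200000 nM.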

Compound 4, half-maximal inhibitory concentration: 1790 nM
Compound 4: the middle estimate sits 22-fold (1.35 log units) above what was measured; the whole stated range lies above it.
By their numbers in this assay, from the lowest: compounds 4, 3 and 2 (each within the scatter of the next). At a limit, above all of these: compound 1.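

The step of a 1.5-fold lower number from compound 2 to compound 4 (0.18 log units; within the scatter) shows that, on a carbon with a double bond to nitrogen, the hydroxyl and methoxy of 3-hydroxy-4-methoxyphenyl are not needed to keep the number in this assay at the level of compound 2, since 2,6-dichlorophenyl, with no hydrogen-bond donor or acceptor, serves as well on the methyl-bearing core. The large step of an at least 22-fold lower number from compound 1 to compound 3 (1.35 log units; beyond the scatter) therefore cannot be read as a general loss for halogen-bearing phenyl groups, and compound 4 is the compound that goes against such a reading. Compound 1 gives > 50000 nM in this assay and this is a limit and not a number, so the size of that step stays open: the limit of > 50000 nM in this assay, at which 1 of the 4 values shown sits.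

The compounds shown leave open whether the gap between compound 1 and compound 4 belongs to the aryl group or to the core substituent, since those two compounds differ in both places. They also leave open how the number responds when an amine or a carboxylic acid stands on the phenyl ring in place of the chlorines.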